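Compound 1 and its piperidin-1-yl counterpart, compound 3

This account rests on a few compounds, and the source may have more. Where it says the series, first, only, none or still open, it means among the compounds named here.

In a functional assay on MCF7 cells (Homo sapiens) for cytotoxicity, read by MTT assay, with a stated time of 72 h (on this read-out lower numbers stand for stronger inhibition and higher numbers for weaker inhibition), compound 1 (`CN(C)CCCCCn1c2c(c3ccccc31)C(=O)c1c[n+]([O-])c3ccccc3c1C2=O`) gives 200 nM. Within the data shown here, compound 2 (`CC1(C)OC[C@H](Cn2cc(Cn3c4c(c5ccccc53)C(=O)c3c[n+]([O-])c5ccccc5c3C4=O)nn2)O1`), the only other measured compound, gives 530 nM. Among the measured compounds shown here, compound 1 holds the lower of the two numbers so far, and the gap between the two lies beyond the scatter. Compound 3 (`O=C1c2c[n+]([O-])c3ccccc3c2C(=O)c2c1c1ccccc1n2CCCCN1CCCCC1`), not yet measured, carries piperidin-1-yl in place of (dimethylamino)methyl on a saturated chain carbon, four bonds along the chain from an aromatic nitrogen. For the measured compounds named here, no measured pair shows this change, so only a small expected step toward a higher number (a 1.3-fold higher number from compound 1 to compound 3 (0.11 log units; within the scatter)) is foreseen, not beyond the scatter. In this assay compound 3 is expected at an estimated 260 nM (range 100 nM to 650 nM).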

Compound 3, half-maximal inhibitory concentration: 150 nM
Beside the measured number, compound 3's estimate is 1.7-fold (0.24 log units) above it; measured number inside the range.
By their numbers in this assay, from the lowest: compounds 3 and 1 (each within the scatter of the next); then compound 2.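

In this assay, among these compounds, the change to piperidin-1-yl in place of (dimethylamino)methyl on a saturated chain carbon, four bonds along the chain from an aromatic nitrogen, gives a 1.3-fold lower number from compound 1 to compound 3 (0.12 log units; within the scatter) in the first measured pair at this position. The larger group, with its six-membered non-aromatic ring, therefore leaves the number within the scatter of the open-chain amine. Nothing at hand explains this result.

The compounds shown leave open how a morpholine ring or a carboxylic acid would read at this place. They also leave open what a longer chain carrying the piperidin-1-yl group would do.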